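Working notes: phenyl in place of cyclopropyl

The source may report more compounds than this note shows. Statements on the series, on what has been measured and on what is new or still open speak of the compounds shown alone.

Measured so far in a physicochemical assay for solubility, in phosphate buffer, measured as kinetic solubility (on this read-out higher numbers stand for higher solubility and lower numbers for lower solubility), for three compounds:
- compound 1 `CC(C)C(c1ccc(-c2ccc3cccc(F)c3c2)[nH]c1=O)C1NC(=O)NC1=O` gives 10600 nM
- compound 2 `CCC(CC)C(/C=C1\OC(=O)NC1=O)c1ccc(-c2ccc3cccc(F)c3c2)[nH]c1=O` gives 33700 nM
- compound 3 `O=C1NC(=O)/C(=C/C(c2ccc(-c3ccc4cccc(F)c4c3)[nH]c2=O)C2CC2)O1` gives 30800 nM

Compound 3 lies within the scatter of compound 2, and compound 1 shows the lower number, beyond the scatter of compound 3. Next comes compound 4 `O=C1NC(=O)/C(=C/C(c2ccccc2)c2ccc(-c3ccc4cccc(F)c4c3)[nH]c2=O)O1`, with phenyl in place of cyclopropyl on a saturated chain carbon bound to an aromatic carbon and a double-bonded chain carbon. Among the measured compounds shown here, only one measured step bears on this place, a 1.1-fold lower number from compound 2 to compound 3 (0.04 log units; within the scatter), and no phenyl example has been measured. No step beyond the scatter is therefore expected in this assay for this change. The expected step is a 1.3-fold lower number from compound 3 to compound 4 (0.11 log units; within the scatter), an estimate resting on that single comparison. For compound 4 the estimated value is 24000 nM, with an expected range from 10000 nM to 50000 nM.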

Compound 4, solubility: 32800 nM
Beside the measured number, compound 4's estimate is 1.4-fold (0.14 log units) below it, and the stated range covers the measured number.
By their numbers in this assay, from the lowest: compound 1; then compounds 3, 4 and 2 (each within the scatter of the next).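

In this assay, the aromatic phenyl reads level with both non-aromatic groups at this place, on a saturated chain carbon bound to an aromatic carbon and a double-bonded chain carbon: against cyclopropyl (a 1.1-fold higher number from compound 3 to compound 4 (0.03 log units; within the scatter)) and against pentan-3-yl (a 1.0-fold lower number from compound 2 to compound 4 (0.01 log units; within the scatter)). Across these three groups, neither ring type nor heavy-atom count separates the numbers beyond the scatter. No supporting data explain this flat result. Open, from the compounds shown here alone, is whether an amine or a carboxylic acid at this place would give a step beyond the scatter.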